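Cytotoxicity notes on the ester analogue with trifluoromethylphenyl

The source may report more compounds than this note shows. Statements on the series, on what has been measured and on what is new or still open speak of the compounds shown alone.

Compound 2 `CCOC(=O)CCCCCOc1cccc(CN(C(=O)c2ccc(-c3cc(OC)ccc3F)cc2)C(C)C)c1` carries an ethyl ester chain and a 2-fluoro-5-methoxyphenyl group. In an ADME assay on Raji cells (Homo sapiens) for cytotoxicity, read by CellTiter-Glo and resazurin assay, with a stated time of 72 h (on this read-out higher numbers stand for an effect only at larger amounts of compound and lower numbers for an effect already at smaller amounts), compound 2 reaches only a limit of > 26000 nM and no number. Compound 1 `CC(C)N(Cc1cccc(OCCCCCC(=O)O)c1)C(=O)c1ccc(-c2cccc(C(F)(F)F)c2)cc1` holds the free acid and a 3-(trifluoromethyl)phenyl group. In this assay compound 1 likewise stops at the limit > 26000 nM. Every value in the set thus sits at the limit of > 26000 nM in this assay, at which 2 of the 2 values shown sit, so compound 2 stands where the whole set stands, and no order between compound 1 and compound 2 can be read. Compound 3 `CCOC(=O)CCCCCOc1cccc(CN(C(=O)c2ccc(-c3cccc(C(F)(F)F)c3)cc2)C(C)C)c1` is not yet measured. The change from compound 2 to compound 3 is 3-(trifluoromethyl)phenyl in place of 2-fluoro-5-methoxyphenyl on an aromatic carbon, while the ethyl ester chain stays. No measured step sizes this change. Both measured compounds sit at the limit, and the expected step that the limit leaves unreadable from compound 2 to compound 3 is none beyond the scatter in this assay. Compound 3 is expected to give 30000 nM in this assay, with a range from 15000 nM to 80000 nM, most probably again reported only as a limit.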

Compound 3, half-maximal effective concentration: > 26000 nM
Compound 3 was reported as a limit; the forecaster's own chance of this, stated with the estimate: 85%; the middle value lies beyond the limit too.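

No new step can be read between compound 3 and compound 1 or compound 2 in this assay, and each of the three is reported only as a limit: the limit of > 26000 nM in this assay, at which 3 of the 3 values shown sit.

The compounds shown leave open whether the ethyl ester and the free acid, or 3-(trifluoromethyl)phenyl and 2-fluoro-5-methoxyphenyl, differ at all in this assay.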